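A ring exchange from compound 2 to compound 3

The source may hold more compounds than are shown below. What is called first, only, known or untested is meant among the compounds shown, and "the series" means these compounds.

In an ADME assay on microsomes from liver (Rattus norvegicus) for metabolic stability, read by LC-MS, using NADPH, with a stated time of 30 min, tested at 1 uM (on this read-out higher numbers stand for fast clearance and lower numbers for slow clearance), compound 1 `CC(C)c1noc(N2CCC(Oc3cc(N4CCc5cc(N6CCCCC6=O)ccc54)ncn3)CC2)n1` gives 13 mL.min-1.g-1 and compound 2 `CC(C)c1noc(N2CCC(Oc3cc(N4CCc5cc(N6CCCNS6(=O)=O)ccc54)ncn3)CC2)n1` gives 21 mL.min-1.g-1. These two numbers lie within the usual scatter of each other, so compound 2 stands level with compound 1. Compound 3 `CC(C)c1noc(N2CCC(Oc3cc(N4CCc5cc(N6CC(O)CCC6=O)ccc54)ncn3)CC2)n1` has not yet been measured. It differs from compound 2 in one place, on an aromatic carbon: a group of 8 heavy atoms (5 carbon, 1 nitrogen, 2 oxygen; one six-membered non-aromatic ring with 1 hetero atom) in place of a group of 8 heavy atoms (3 carbon, 2 nitrogen, 2 oxygen, 1 sulfur; one six-membered non-aromatic ring with 3 hetero atoms), on an aromatic carbon. The entering 5-hydroxy-2-oxopiperidin-1-yl group is the ring of compound 1 with a hydroxy group added. Within the data shown here, the one measured step that bears on this exchange, a 1.6-fold higher number from compound 1 to compound 2 (0.21 log units; within the scatter), stayed within the scatter. Among the measured compounds shown here, no measured compound shows what the hydroxy group does, so no change beyond the scatter is expected in this assay. The expected step is a 1.5-fold lower number from compound 2 to compound 3 (0.18 log units; within the scatter), which is within the scatter. For compound 3 the estimated value is 14 mL.min-1.g-1, with an expected range from 7 mL.min-1.g-1 to 28 mL.min-1.g-1.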

Compound 3, intrinsic clearance in microsomes in the Rattus norvegicus assay: 7 mL.min-1.g-1
Beside the measured number, compound 3's estimate is 2.0-fold (0.30 log units) above it, and the stated range covers the measured number.
By their numbers in the Rattus norvegicus assay, from the lowest: compounds 3, 1 and 2 (each within the scatter of the next, the first and the last beyond it).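

Among these compounds, in the Rattus norvegicus assay, the exchange of rings on this aromatic carbon gives the first step beyond the scatter: a 3.0-fold lower number from compound 2 to compound 3 (0.48 log units; beyond the scatter). In the Rattus norvegicus assay, hydroxy in place of hydrogen on a saturated ring carbon gives a 1.9-fold lower number from compound 1 to compound 3 (0.27 log units; within the scatter), so the added hydroxy alone cannot be told apart from the scatter, and the clear step appears only between the two end compounds of the series. In a physicochemical assay for lipophilicity, measured as octanol-water partition, at pH 7.4 (on this read-out lower numbers stand for lower lipophilicity and higher numbers for higher lipophilicity), compound 2 gives 3.2 and compound 3 gives 2.6. The same exchange also lowers lipophilicity in the physicochemical assay: the measured distribution coefficient of compound 2, 3.2, and of compound 3, 2.6, a number 0.60 log units lower (beyond the scatter)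

The compounds shown leave open whether an amine or a carboxylic acid in place of the hydroxy on the saturated ring would give a similar intrinsic clearance. They also leave open whether intrinsic clearance would follow the distribution coefficient across a wider set of rings at this position.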